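This account rests on a few compounds, and the source may have more. Where it says the series, first, only, none or still open, it means among the compounds named here.

In a functional assay on SNB-19 cells (Homo sapiens) for inhibition, read by sulforhodamine B assay, with a stated time of 48 h, tested at 10 uM (on this read-out lower numbers stand for less inhibition and higher numbers for more inhibition at the one concentration tested (going by the name of the read-out)), three compounds built on one shared core have been measured. Compound 1 `c1ccc(-c2cn3ccnc3c(-c3ccc4ncn(C5CCCCC5)c4c3)n2)cc1` gives 22.9%, compound 2 `O=Cc1ccc(-c2cn3ccnc3c(-c3ccc4ncn(C5CCCCC5)c4c3)n2)cc1` gives 14.4%, and compound 3 `Fc1ccccc1-c1cn2ccnc2c(-c2ccc3ncn(C4CCCCC4)c3c2)n1` gives 7.56%. Compound 2 stands second highest of the three numbers: compound 3 is its nearest neighbour, and the step of a number 6.8 percentage points lower from compound 2 to compound 3 (within the scatter) lies within the scatter, while compound 1 is its furthest neighbour, and the step of a number 8.5 percentage points lower from compound 1 to compound 2 (within the scatter) also lies within the scatter. Among the measured compounds shown here, only the step of a number 15.3 percentage points lower from compound 1 to compound 3 (beyond the scatter) goes beyond it.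

Compound 4 `FC(F)(F)c1cccc(-c2cn3ccnc3c(-c3ccc4ncn(C5CCCCC5)c4c3)n2)c1` has not yet been measured in this assay. It differs from compound 2 by 3-(trifluoromethyl)phenyl in place of 4-formylphenyl on an aromatic carbon. All three measured steps bear on this change, since each of them alters the group on that same aromatic carbon of the core, and each of them moved the number downward, by a small amount in two cases and by a modest amount in one. The same kind of exchange in compound 4 is therefore expected to give a step that is small and downward, most likely staying within the scatter, so that a number 3.4 percentage points lower from compound 2 to compound 4 (within the scatter) is the estimated outcome. On that basis compound 4 is expected to give about 11% in this assay, with a range from 0% to 26%.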

Compound 4, a percentage reported as inhibition, at one concentration (the size of the read-out at that concentration, not a potency): 2.24%
For compound 4 the middle estimate is 8.8 percentage points above the measured one, and the stated range covers the measured number.
By their numbers in this assay, from the lowest: compounds 4, 3, 2 and 1 (each within the scatter of the next, the first and the last beyond it).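

In this assay, trifluoromethyl in place of hydrogen on the phenyl group gave a number 20.7 percentage points lower from compound 1 to compound 4 (beyond the scatter), the largest step among these compounds, while 3-(trifluoromethyl)phenyl in place of 4-formylphenyl gave a number 12.2 percentage points lower from compound 2 to compound 4 (beyond the scatter), the first step from compound 2 to go beyond the scatter. The exchange of 2-fluorophenyl for 3-(trifluoromethyl)phenyl gave a number 5.3 percentage points lower from compound 3 to compound 4 (within the scatter), so the two fluorine-bearing phenyl groups cannot be told apart here, and both now stand beyond the scatter from the unsubstituted phenyl of compound 1, a separation that compound 2, with its formyl group, does not show. Nothing available explains why this aromatic carbon responds in this way.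

As far as these compounds go, what remains open is whether the trifluoromethyl group itself or its place on the phenyl ring sets the number, as the fluoro and trifluoromethyl compounds differ in both the group and where it stands. From the compounds shown here alone, it is also open whether an amine or a carboxylic acid on the same phenyl ring would keep the number near that of compound 1 or move it as the fluorine-bearing groups do.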